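A few compounds are considered here, and "the series" means these few. Any claim that something is new, unique, unknown or untested is made for them only; others in the source may bear on it.

Measured so far:
compound 1, `O=C(O)Cc1sc(COc2ccc(Cl)cc2)nc1-c1ccc(Cl)cc1`, 32 nM in an in vitro assay on HEK385-7 cells for displacement of a labelled ligand from prostaglandin D2 receptor 2 (Homo sapiens); on this read-out lower numbers stand for stronger inhibition and higher numbers for weaker inhibition
compound 2, `O=C(O)Cc1sc(C(c2ccc(F)cc2)c2ccc(F)cc2)nc1-c1cccc(F)c1`, 1.4 nM in this assay
compound 3, `N#Cc1cc(-c2nc(C(c3ccc(F)cc3)c3ccc(F)cc3)sc2CC(=O)O)ccc1F`, 57 nM in this assay

All three share one core bearing a carboxymethyl group, and they differ in the aromatic group attached next to the ring nitrogen. Compound 3 gives the highest number of the three in this assay; compound 1 sits within the scatter of it, while compound 2 lies far below, so compound 2 is clearly the strongest binder of this set.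

The step to compound 4, `O=C(O)Cc1sc(C(c2ccc(F)cc2)c2ccc(F)cc2)nc1-c1ccncc1`, is pyridin-4-yl in place of 3-cyano-4-fluorophenyl on an aromatic carbon. For the measured compounds named here, the only measured step at this position is a 41-fold higher number from compound 2 to compound 3 (1.61 log units; beyond the scatter), which shows that the aromatic group here can move the number a great deal. Pyridin-4-yl has not been measured, and no step from a fluorinated phenyl to a pyridine exists in these data, so the direction is uncertain. Compound 2 shows that a plain six-membered ring with one small substituent can give a very low number, whereas compound 3 with the cyano-fluoro ring gives a high one. On balance a modest decrease, a 2.9-fold lower number from compound 3 to compound 4 (0.45 log units; beyond the scatter), is expected for compound 4, with wide uncertainty. Compound 4 is therefore estimated at 20 nM, likely between 4 nM and 100 nM.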

Compound 4, half-maximal inhibitory concentration: 5.3 nM
Beside the measured number, compound 4's estimate is 3.8-fold (0.58 log units) above it; measured number inside the range.
By their numbers in this assay, from the lowest: compound 2; then compound 4; then compounds 1 and 3 (each within the scatter of the next).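

In this assay, putting pyridin-4-yl in place of 3-cyano-4-fluorophenyl gives an 11-fold lower number from compound 3 to compound 4 (1.03 log units; beyond the scatter), so this position also accepts a ring with a nitrogen atom in it, and a low number does not depend on an all-carbon ring. Measured against the best compound here, the same group gives a 3.8-fold higher number from compound 2 to compound 4 (0.58 log units; beyond the scatter), a much smaller loss than a 41-fold higher number from compound 2 to compound 3 (1.61 log units; beyond the scatter), so the large penalty seen earlier belongs to the 3-cyano-4-fluorophenyl group and not to every change away from 3-fluorophenyl. No supporting information on why these groups differ is available, so the numbers record the size of each change without explaining it.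

The compounds shown leave open which part of 3-cyano-4-fluorophenyl carries the penalty, since a ring bearing only the nitrile or only a fluorine at the 4-position would separate the two. They also leave open how an unsubstituted phenyl or a pyridin-3-yl would compare with pyridin-4-yl, and so whether the place of the ring nitrogen matters.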